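A few compounds are considered here, and "the series" means these few. Any claim that something is new, unique, unknown or untested is made for them only; others in the source may bear on it.

Measured so far in an assay on a protein complex for inhibition of ubiquitin carboxyl-terminal hydrolase 1/WD repeat-containing protein 48 (Homo sapiens), read by fluorescence; on this read-out lower numbers stand for stronger inhibition and higher numbers for weaker inhibition:
- compound 1, `FC(F)(F)c1ccccc1-c1nc(NCc2ccc(-c3ccc(Cl)cc3)cc2)c2ccccc2n1`: 3600 nM
- compound 2, `FC(F)(F)c1ccccc1-c1nc(NCc2ccc(-c3cccc(Cl)c3)cc2)c2ccccc2n1`: 2700 nM

Compound 2 gives the lowest of the two numbers in this assay, with compound 1 sitting within the scatter of it. Within the data shown here, the only measured step, a 1.3-fold lower number from compound 1 to compound 2 (0.12 log units; within the scatter), swaps the chlorine position on the outer ring and does not move the number beyond the scatter.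

Compound 3, `FC(F)(F)c1ccccc1-c1nc(NCc2ccc(C3CCCCC3)cc2)c2ccccc2n1`, is not yet measured. The change from compound 2 to compound 3 is cyclohexyl in place of 3-chlorophenyl on an aromatic carbon. Among the measured compounds shown here, no measured step bears on replacing the outer aromatic ring with a non-aromatic one, so the expectation rests on the single nearby pair alone. Compound 3 is expected to give about 3500 nM in this assay, between 1000 nM and 12000 nM, a step of a 1.3-fold higher number from compound 2 to compound 3 (0.11 log units; within the scatter), with wide uncertainty.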

Compound 3, half-maximal inhibitory concentration: 9800 nM
Compound 3: the middle estimate sits 2.8-fold (0.45 log units) below what was measured; measured number inside the range.
By their numbers in this assay, from the lowest: compounds 2 and 1 (each within the scatter of the next); then compound 3.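

At this position, para to a large group, the nature of the outer ring counts for more than the chlorine placement did: this assay shows a 3.6-fold higher number from compound 2 to compound 3 (0.56 log units; beyond the scatter) and a 2.7-fold higher number from compound 1 to compound 3 (0.43 log units; beyond the scatter) on going to cyclohexyl. A six-membered non-aromatic ring of carbon only therefore keeps measurable inhibition, at a modest loss against both chlorophenyl compounds. Nothing measured here accounts for the shift. The compounds shown leave open whether the aromatic ring or its chlorine carries the difference, a question for unsubstituted phenyl. From the compounds shown here alone, how a piperidine or a morpholine would fare at this place also remains open.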